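The source may report more compounds than this note shows. Statements on the series, on what has been measured and on what is new or still open speak of the compounds shown alone.

Measured in a functional assay on KG-1 cells (Homo sapiens) for cytotoxicity, read by luminescence and CellTiter-Glo, with a stated time of 3 days; on this read-out higher numbers stand for weaker inhibition and lower numbers for stronger inhibition:
compound 1 `N#Cc1ccc(NC(=O)c2ccc(Br)cc2O)c(Cl)c1`: 790 nM
compound 2 `N#Cc1cccc(NC(=O)c2cc(F)ccc2O)c1`: 9100 nM
compound 3 `N#Cc1ccc(NC(=O)c2ccc(Br)cc2O)cc1Cl`: 960 nM

Compound 2 has the highest number of the three, and its gaps to compound 1 and compound 3 both lie beyond the scatter, so it is the weakest so far. Compound 4 `O=C(Nc1cccc(OC(F)(F)F)c1)c1cc(F)ccc1O` carries trifluoromethoxy in place of cyano on an aromatic carbon, meta to a large group: trifluoromethoxy in place of cyano on an aromatic carbon. For the measured compounds named here, no two measured compounds differ in only one place, so the data do not isolate this change. Compound 2 stands high at 9100 nM, so a moderate step toward a lower number in this assay is expected, though with little certainty. The estimate means an expected 3.0-fold lower number from compound 2 to compound 4 (0.48 log units; beyond the scatter). For compound 4 the estimated value is 3000 nM, with a range from 900 nM to 9000 nM.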

Compound 4, half-maximal inhibitory concentration: 830 nM
For compound 4 the middle estimate is 3.6-fold (0.56 log units) above the measured one; the whole stated range lies above it.
By their numbers in this assay, from the lowest: compounds 1, 4 and 3 (each within the scatter of the next); then compound 2.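

In this assay, for the compounds shown here, trifluoromethoxy in place of cyano on this aromatic carbon gives an 11-fold lower number from compound 2 to compound 4 (1.04 log units; beyond the scatter), a large step and the only single change that can be read so far. The number at this position therefore depends clearly on the group placed there, at least on the core of compound 2. Nothing at hand explains why the number moves.

On these data alone, only these two groups can be compared here, so it remains open how an amine, a carboxylic acid or a plain methoxy group would fare at this position. As far as these compounds go, it is also open whether the same swap would give a similar step on the core of compound 1.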